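Adding a Methyl Group to Compound 3

The source may hold more compounds than are shown below. What is called first, only, known or untested is meant among the compounds shown, and "the series" means these compounds.

Of the compounds shown here, three sharing one core have been measured in a functional assay on MDA-MB-231 cells (Homo sapiens) for inhibition, read by MTT assay, with a stated time of 72 h, tested at 20 uM; on this read-out higher numbers stand for more inhibition at the one concentration tested (going by the name of the read-out) and lower numbers for less inhibition. Compound 2 `c1cc(N2CCCC2)nc(Nc2ccc(Oc3ncnc4sccc34)cc2)n1` gives 24.7%. Compound 1 `CN(c1ccc(Oc2ncnc3sccc23)cc1)c1nccc(N2CCCC2)n1` differs from compound 2 by methyl in place of hydrogen on a nitrogen on an aromatic ring, and compound 1 gives 31%; the step of a number 6.3 percentage points higher from compound 2 to compound 1 (within the scatter). Compound 3 `c1ccc2c(c1)CCN2c1ccnc(Nc2ccc(Oc3ncnc4sccc34)cc2)n1` differs from compound 2 by 2,3-dihydro-1H-indol-1-yl in place of pyrrolidin-1-yl on an aromatic carbon, and compound 3 gives 9.95%, the step being a number 14.8 percentage points lower from compound 2 to compound 3 (beyond the scatter), so compound 3 stands lowest of the three.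

Compound 4 `CN(c1ccc(Oc2ncnc3sccc23)cc1)c1nccc(N2CCc3ccccc32)n1` has not yet been measured. It differs from compound 3 by methyl in place of hydrogen on a nitrogen on an aromatic ring. This is the same change that separates compound 2 from compound 1, and the place where it occurs is described in the same words in both pairs; the two cores differ only in the way given above for compound 3 against compound 2. The change occurs twice among these compounds, and its one measured step is within the scatter.

Going by the values given here, with only a single prior example, the expectation for compound 4 rests on that step alone. Because a number 6.3 percentage points higher from compound 2 to compound 1 (within the scatter), the step from compound 3 to compound 4 is expected to be a number 6.1 percentage points higher from compound 3 to compound 4 (within the scatter), which is again within the scatter. Compound 4 is therefore estimated to give 16%, with a likely range from 5% to 28%.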

Compound 4, a percentage reported as inhibition, at one concentration (the size of the read-out at that concentration, not a potency): 17.7%
Compound 4: middle estimate off by 1.7 percentage points, on the low side; the measured number falls inside the stated range.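

In this assay, methyl in place of hydrogen on the nitrogen gives a number 7.8 percentage points higher from compound 3 to compound 4 (within the scatter), and this step is much the same size as the one seen earlier on the other core: the same change on two cores in this assay, a number 6.3 percentage points higher (within the scatter) from compound 2 to compound 1 and a number 7.8 percentage points higher (within the scatter) from compound 3 to compound 4, 1.5 percentage points apart, within the scatter of two such steps. The other change in the set also carries over, since 2,3-dihydro-1H-indol-1-yl in place of pyrrolidin-1-yl, now read on the two methylated compounds, gives a number 13.3 percentage points lower from compound 1 to compound 4 (beyond the scatter), and it matches its earlier counterpart: the same change on two cores in this assay, a number 14.8 percentage points lower (beyond the scatter) from compound 2 to compound 3 and a number 13.3 percentage points lower (beyond the scatter) from compound 1 to compound 4, 1.5 percentage points apart, within the scatter of two such steps. Together these steps show that, across these four compounds, each change has about the same size on either core, but both methyl steps lie within the scatter, so they do not show that the methyl really raises the inhibition, and two cores at a single concentration cannot show how the change would behave on any further core or what it does to potency.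

The compounds shown leave open what an ethyl group or a longer chain would do on that nitrogen in place of the methyl. They also leave open whether an open-chain amine on the aromatic carbon, in place of pyrrolidin-1-yl or 2,3-dihydro-1H-indol-1-yl, would follow the same pattern.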